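The compounds below may be only part of what the source reports. "The series", "measured", "known", "first", "only" and "open" are said of these compounds alone.

Measured compounds:
compound 1, `COc1ccc(CNC(=O)/C(C#N)=C/c2ccc(Br)o2)cc1`, 16000 nM in a functional assay on MIA cells (Homo sapiens) for inhibition, read by MTT assay, with a stated time of 72 h; on this read-out lower numbers stand for stronger inhibition of growth and higher numbers for weaker inhibition of growth
compound 2, `COc1ccc(CNC(=O)/C(C#N)=C/c2cc(Br)co2)cc1`, 65000 nM in this assay

Compound 2 holds the highest number of the two measured in this assay; its nearest neighbour is compound 1, and the step of a 4.1-fold higher number from compound 1 to compound 2 (0.61 log units; beyond the scatter) is the only one recorded and runs beyond the scatter. It concerns only the position of the bromine on the furan ring; nothing measured yet touches the shared core with a ring of carbon only on the double-bonded chain carbon.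

Compound 3, `COc1ccc(CNC(=O)/C(C#N)=C/c2ccc(C)cc2)cc1`, is the next to be measured. It differs from compound 2 as follows: 4-methylphenyl in place of 4-bromofuran-2-yl on a double-bonded chain carbon bound to a double-bonded chain carbon. Among the measured compounds shown here, no recorded step bears directly on an exchange of a five-membered ring with one hetero atom for a six-membered ring of carbon only, so the expectation rests on the spread between compound 1 and compound 2 alone. For the measured compounds named here, because the whole series so far spans a 4.1-fold higher number from compound 1 to compound 2 (0.61 log units; beyond the scatter), compound 3 is expected to land within or near that band, most likely somewhat below compound 2, with the expected step of a 2.2-fold lower number from compound 2 to compound 3 (0.34 log units; beyond the scatter) in this assay. The estimate for compound 3 is 30000 nM, in a range from 8000 nM to 120000 nM.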

Compound 3, concentration for 50% growth inhibition: 38000 nM
The estimate for compound 3 lay 1.3-fold (0.10 log units) below the measured number, within the range that was stated.
By their numbers in this assay, from the lowest: compound 1; then compounds 3 and 2 (each within the scatter of the next).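

At the position on a double-bonded chain carbon bound to a double-bonded chain carbon, 4-methylphenyl shows that a six-membered aromatic ring of carbon only can replace 4-bromofuran-2-yl without a resolved change in this assay, with a 1.7-fold lower number from compound 2 to compound 3 (0.23 log units; within the scatter) lying within the scatter. Against 5-bromofuran-2-yl the same exchange is resolved, with a 2.4-fold higher number from compound 1 to compound 3 (0.38 log units; beyond the scatter) lying beyond the scatter, so compound 1 now stands apart from both compound 2 and compound 3, while those two cannot be ordered. No supporting evidence accounts for this result.

The three compounds do not separate the contribution of the ring from that of its substituent, so a plain phenyl ring, a 4-bromophenyl ring or a 5-methylfuran-2-yl group would be needed to tell whether the standing of compound 1 goes with the furan ring, the bromine or the combination of the two. As far as these compounds go, how this position responds to a ring carrying an amine or a carboxylic acid also stays open, as do changes to the shared core outside this position.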